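Methoxy for chloro on the aryl of compound 2

The source may report more compounds than this note shows. Statements on the series, on what has been measured and on what is new or still open speak of the compounds shown alone.

Among the compounds with values here, compound 2 `O=C(/C=C\Nc1ccc(Cl)cc1)c1cn(-c2ccccc2)nc1-c1ccc(Cl)cc1` gives 3670 nM in a functional assay on A549 cells (Homo sapiens) for antiproliferative activity, read by MTT assay, with a stated time of 48 h (on this read-out higher numbers stand for weaker inhibition and lower numbers for stronger inhibition), the lower of the two numbers so far. Compound 1 `O=C(/C=C\Nc1ccc(Cl)cc1)c1cn(-c2ccccc2)nc1-c1ccccc1` gives 14100 nM in this assay. The one step shown, a 3.8-fold lower number from compound 1 to compound 2 (0.58 log units; beyond the scatter), is chloro in place of hydrogen on an aromatic carbon. Compound 3 `COc1ccc(-c2nn(-c3ccccc3)cc2C(=O)/C=C\Nc2ccc(Cl)cc2)cc1` differs from compound 2 by methoxy in place of chloro on an aromatic carbon. Within the data shown here, no measured step exchanges one substituent for another at this place, so how much of the gain seen with chloro a methoxy keeps is open. The expected step is modest, a 1.8-fold higher number from compound 2 to compound 3 (0.25 log units; within the scatter). For compound 3 the estimate is 6500 nM, with a range of 2200 nM to 19000 nM.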

Compound 3, half-maximal inhibitory concentration: 2970 nM
Compound 3: the middle estimate sits 2.2-fold (0.34 log units) above what was measured, and the stated range covers the measured number.
By their numbers in this assay, from the lowest: compounds 3 and 2 (each within the scatter of the next); then compound 1.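

Exchanging the 4-chlorophenyl for the 4-methoxyphenyl gives a 1.2-fold lower number from compound 2 to compound 3 (0.09 log units; within the scatter) in this assay, so the two groups cannot be told apart here. Methoxy in place of hydrogen gives a 4.7-fold lower number from compound 1 to compound 3 (0.68 log units; beyond the scatter), which shows that the gain at this position is not confined to chloro. No evidence bears on why the two groups read alike.

From the compounds shown here alone, it remains open whether an amine, a carboxylic acid or a longer chain such as ethoxy would keep this gain. The compounds shown also leave open whether the result extends beyond this one cell line.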